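The source may hold more compounds than are shown below. What is called first, only, known or untested is meant among the compounds shown, and "the series" means these compounds.

Measured compounds:
compound 1 `Cc1ccccc1-n1nncc1CN1C(=O)C2(C(C#N)=C(N)Oc3c2c2nc4ccccc4nc2c2ccccc32)c2ccccc21` gives > 50000 nM
compound 2 `N#CC1=C(N)Oc2c(c3nc4ccccc4nc3c3ccccc23)C12C(=O)N(Cc1cnnn1-c1ccc(F)cc1)c1ccccc12` gives > 50000 nM
compound 3 `N#CC1=C(N)Oc2c(c3nc4ccccc4nc3c3ccccc23)C12C(=O)N(Cc1cnnn1-c1cccc(Cl)c1)c1ccccc12` gives 43600 nM

In a functional assay on MCF7 cells (Homo sapiens) for antiproliferative activity, read by MTT assay, with a stated time of 48 h (on this read-out lower numbers stand for stronger inhibition and higher numbers for weaker inhibition), the value of compound 1 is a limit of the assay, not a number. The value of compound 2 is likewise a limit. Among the measured compounds shown here, compound 3 is the only member of the three with a number in this assay, and that number sits close to the limit. The step that the two limits leave unreadable from compound 1 to compound 2 cannot be read. The steps of an at least 1.1-fold lower number from compound 1 to compound 3 (0.05 log units; that floor lies within the scatter) and an at least 1.1-fold lower number from compound 2 to compound 3 (0.05 log units; that floor lies within the scatter) have floors that stay within the scatter, so none of the three aryl groups on the aromatic nitrogen is shown to set itself apart; the limit of > 50000 nM in this assay, at which 2 of the 3 values shown sit, caps what can be read here.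

Compound 4 `N#CC1=C(N)Oc2c(c3nc4ccccc4nc3c3ccccc23)C12C(=O)N(Cc1cnnn1-c1ccc(Br)cc1)c1ccccc12` is the next variation at the same place: 4-bromophenyl in place of 3-chlorophenyl on an aromatic nitrogen. The three measured steps all exchange the aryl group on that nitrogen and none reads as a change beyond the scatter, so the step of a 1.1-fold higher number from compound 3 to compound 4 (0.06 log units; within the scatter) is expected to be of no readable size in this assay. Compound 4 is therefore estimated at 50000 nM, within 20000 nM to 150000 nM, with a real chance that only a limit is reported.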

Compound 4, half-maximal inhibitory concentration: 36600 nM
Estimate against measurement, compound 4: 1.4-fold (0.14 log units) above, and the stated range covers the measured number.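

In this assay, among the compounds shown here, the exchange of 3-chlorophenyl for 4-bromophenyl on the aromatic nitrogen is the first step at this position with a number at both ends (a 1.2-fold lower number from compound 3 to compound 4 (0.08 log units; within the scatter)), and it shows no readable change. The values of compound 1 and compound 2 are limits of the assay, so the steps that end at compound 4 give only floors (an at least 1.3-fold lower number from compound 2 to compound 4 (0.13 log units; that floor lies within the scatter); an at least 1.3-fold lower number from compound 1 to compound 4 (0.13 log units; that floor lies within the scatter)), and both stay within the scatter. None of the four aryl groups is therefore shown to set itself apart, and what can be read remains capped: the limit of > 50000 nM in this assay, at which 2 of the 4 values shown sit.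

Going by these compounds, it remains open whether an aryl group carrying an amine or a carboxylic acid, or a longer alkyl chain in place of the aryl group, would move the number beyond the scatter in this assay. Also open, on these data alone, is whether a change on the shared core would take the series clear of the limit.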